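From phenoxy to chloro: estimating compound 4

The source may hold more compounds than are shown below. What is called first, only, known or untested is meant among the compounds shown, and "the series" means these compounds.

Measured so far:
Compound 1 `CCOC(=O)c1c(-c2cccc(Oc3ccccc3)c2)[nH]c2cc(OC)ccc2c1=O`: 4300 nM
Compound 2 `CCOC(=O)c1c(-c2cccc(Cl)c2)[nH]c2cc(OC)ccc2c1=O`: 58000 nM
Compound 3 `CCOC(=O)c1c(-c2cccc(Oc3ccccc3)c2)[nH]c2cc(OC)c(F)cc2c1=O`: 4300 nM

In a physicochemical assay for solubility, at pH 7.4 (a higher number here means a more soluble compound, a lower number a less soluble compound), compound 3 gives 4300 nM, which matches compound 1 and sits under the value of compound 2. Compound 4 `CCOC(=O)c1c(-c2cccc(Cl)c2)[nH]c2cc(OC)c(F)cc2c1=O` carries chloro in place of phenoxy on an aromatic carbon, meta to a large group: chloro in place of phenoxy on an aromatic carbon. The same swap, made without the fluoro, gave a 13-fold higher number from compound 1 to compound 2 (1.13 log units; beyond the scatter), a large step beyond the scatter. Fluoro in place of hydrogen gave no change at the digits printed from compound 1 to compound 3 (within the scatter), which is within the scatter. Going by the step to compound 2, a similarly large rise is expected, though only these two steps support it. The expected step is a 13-fold higher number from compound 3 to compound 4 (1.11 log units; beyond the scatter). Compound 4 is estimated at 55000 nM, with an expected range of 25000 nM to 110000 nM.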

Compound 4, solubility: 20000 nM
Compound 4: the middle estimate sits 2.8-fold (0.44 log units) above what was measured, and the stated range ends above it.
By their numbers in this assay, from the lowest: compounds 1 and 3 (each within the scatter of the next); then compound 4; then compound 2.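

With the fluoro present, chloro in place of phenoxy still raises the number, a 4.7-fold higher number from compound 3 to compound 4 (0.67 log units; beyond the scatter), but this modest step is smaller than the large one seen without the fluoro, a 13-fold higher number from compound 1 to compound 2 (1.13 log units; beyond the scatter). The fluoro, which changed nothing alongside phenoxy, gives a 2.9-fold lower number from compound 2 to compound 4 (0.46 log units; beyond the scatter) alongside chloro, so the two changes do not act independently across these compounds. Nothing available explains this dependence. As far as these compounds go, whether it extends to other groups on that aromatic carbon, such as an amine or a carboxylic acid, remains open.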